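A few compounds are considered here, and "the series" means these few. Any claim that something is new, unique, unknown or untested is made for them only; others in the source may bear on it.

Compound 1 `COc1ccc(-c2ccc(OCc3cc(C(=O)NS(=O)(=O)c4ccccc4)oc3C)cc2)c(C)c1` is the starting point. In an assay on cells for displacement of a labelled ligand from prostaglandin E2 receptor EP4 subtype (Homo sapiens), read by scintillation counting (on this read-out higher numbers stand for weaker inhibition and lower numbers for stronger inhibition), compound 1 gives 21 nM, and compound 2 `CC(=O)c1ccc(-c2ccc(OCc3cc(C(=O)NS(=O)(=O)c4ccccc4)oc3C)cc2)cc1` gives 20 nM; these two numbers sit together, as the step of a 1.1-fold lower number from compound 1 to compound 2 (0.02 log units; within the scatter) shows. Compound 3 `COc1ccc(-c2ccc(OCc3cc(C(=O)NS(=O)(=O)c4c(C)noc4C)oc3C)cc2)c(C)c1` differs from compound 1 by 3,5-dimethyl-1,2-oxazol-4-yl in place of phenyl on a sulfonyl sulfur. For the measured compounds named here, the only measured step, a 1.1-fold lower number from compound 1 to compound 2 (0.02 log units; within the scatter), changes a different part of the molecule, so nothing measured bears directly on the sulfonyl group. For compound 3 the expected step is therefore a 1.4-fold higher number from compound 1 to compound 3 (0.15 log units; within the scatter), no change beyond the scatter, and its estimated value in this assay is 30 nM, between 8 nM and 120 nM.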

Compound 3, inhibition constant: 24 nM
For compound 3 the middle estimate is 1.3-fold (0.10 log units) above the measured one, and the stated range covers the measured number.
By their numbers in this assay, from the lowest: compounds 2, 1 and 3 (each within the scatter of the next).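

The first step measured on the sulfonyl sulfur shows that in this assay the phenyl can give way to 3,5-dimethyl-1,2-oxazol-4-yl with no change beyond the scatter (a 1.1-fold higher number from compound 1 to compound 3 (0.06 log units; within the scatter)). So at this place, a five-membered aromatic ring with 2 hetero atoms and a six-membered aromatic ring of carbon only read alike. Nothing available explains this result.

Going by these compounds, what a plain methyl group or an aminophenyl group would give on the sulfonyl sulfur stays open. So does whether this exchange reads the same alongside the 4-acetylphenyl of compound 2.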